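Cyclohexyl in place of methyl on the thioether chain

The source may report more compounds than this note shows. Statements on the series, on what has been measured and on what is new or still open speak of the compounds shown alone.

Of the compounds shown here, three built on a shared core have been measured in a functional assay on MGC-803 cells (Homo sapiens) for inhibition, read by MTT assay, with a stated time of 72 h; a higher number here means a weaker inhibitor, a lower number a stronger inhibitor. Compound 1 `C#CCSc1nc(Nc2ccc(Cl)cc2)c2ccncc2n1` gives 16400 nM, and compound 2 `C#CCSc1nc(N2CCN(CC)CC2)c2ccncc2n1` gives 70600 nM. Compound 3 `CCSc1nc(Nc2cccc(OC)c2)c2ccncc2n1` gives 590 nM, the lowest of the three numbers, with its gaps to both other compounds beyond the scatter, so it stands as the strongest inhibitor of the group. Compound 4 `COc1cccc(Nc2nc(SCC3CCCCC3)nc3cnccc23)c1` has not yet been measured. It differs from compound 3 by one change: cyclohexyl in place of methyl on a saturated chain carbon bound to a sulfur. Going by the values given here, no pair of measured compounds differs in a single place, so no measured step guides the expectation. The expected step is a 1.5-fold higher number from compound 3 to compound 4 (0.18 log units; within the scatter), modest and of uncertain direction, possibly within the scatter. Compound 4 is therefore estimated at 900 nM in this assay, in a range from 200 nM to 5000 nM.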

Compound 4, half-maximal inhibitory concentration: 23700 nM
Estimate against measurement, compound 4: 26-fold (1.42 log units) below; measured number above the stated range.
By their numbers in this assay, from the lowest: compound 3; then compounds 1 and 4 (each within the scatter of the next); then compound 2.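

In this assay the thioether chain turns out to be a sensitive position: cyclohexyl in place of methyl on a saturated chain carbon bound to a sulfur gives a 40-fold higher number from compound 3 to compound 4 (1.60 log units; beyond the scatter) through this one change alone. The earlier compounds shown here, none differing in a single place, could not show this. Nothing available explains the loss of inhibition.

The compounds shown leave open how a group such as ethyl, phenyl or a terminal amine would fare on that carbon. They also leave open whether cyclohexyl has the same effect with a different group in place of the methoxyphenyl amine of compound 3.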